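Replacing 2-Fluorophenyl with Cyclohexyl on a Ring Amine Nitrogen

The source may report more compounds than this note shows. Statements on the series, on what has been measured and on what is new or still open speak of the compounds shown alone.

Of the compounds shown here, two have been measured so far. Compound 1 `Nc1ccccc1NC(=O)c1ccc(CSC(=S)N2CCN(Cc3ccccn3)CC2)cc1` gives 82.4% in a functional assay on A-375 cells (Homo sapiens) for antiproliferative activity, read by CCK-8 assay, with a stated time of 72 h, tested at 8 uM; on this read-out higher numbers stand for a stronger effect at the one concentration tested and lower numbers for a weaker effect. Compound 2 `Nc1ccccc1NC(=O)c1ccc(CSC(=S)N2CCN(c3ccccc3F)CC2)cc1` gives 79.5% in the same assay. Among the measured compounds shown here, the one step between them, a number 2.9 percentage points lower from compound 1 to compound 2 (within the scatter), changed only the group on the ring amine nitrogen and left the read-out essentially unchanged. For the measured compounds named here, compound 2 therefore stands level with compound 1 within the scatter, these being the only two numbers available.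

Compound 3 `Nc1ccccc1NC(=O)c1ccc(CSC(=S)N2CCN(C3CCCCC3)CC2)cc1` is the next step from compound 2: cyclohexyl in place of 2-fluorophenyl on an amine nitrogen in a ring. Going by the values given here, the only measured step that bears on it is the exchange at the same ring nitrogen, from compound 1 to compound 2, and that step, a number 2.9 percentage points lower from compound 1 to compound 2 (within the scatter), stayed within the scatter. With nothing else to draw on, the account expects the step of a number 2.5 percentage points lower from compound 2 to compound 3 (within the scatter) to be no larger than that, and not beyond the scatter in either direction. Compound 3 is accordingly estimated to give 77% in this assay, within a range from 62% to 90%.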

Compound 3, a percentage reported as inhibition, at one concentration (the size of the read-out at that concentration, not a potency): 89.9%
The estimate for compound 3 lay 12.9 percentage points below the measured number, within the range that was stated.
By their numbers in this assay, from the lowest: compounds 2, 1 and 3 (each within the scatter of the next, the first and the last beyond it).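

At the amine nitrogen in the ring, cyclohexyl in place of 2-fluorophenyl gives the first step in this assay to pass beyond the scatter (a number 10.4 percentage points higher from compound 2 to compound 3 (beyond the scatter)), a modest one, so this position is shown not to be indifferent to the group it carries, as the earlier step alone had suggested. Cyclohexyl in place of (pyridin-2-yl)methyl, by contrast, stays within the scatter (a number 7.5 percentage points higher from compound 1 to compound 3 (within the scatter)), so compound 3, with its one six-membered non-aromatic ring of carbon only on that nitrogen, stands level with compound 1, and an aromatic ring in this group is not required to reach that level of inhibition at the one concentration tested. No measurement is available here that would explain why these groups compare as they do.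

The step from compound 2 to compound 3 removes the fluorine and the aromatic ring together, so the compounds shown cannot separate the two, and a plain phenyl group on the same nitrogen would be needed to tell them apart. They also leave open whether a ring of carbon is needed at all or whether an open chain such as hexyl, or a smaller ring such as cyclopentyl, would serve the position equally well.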